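Swapping the ring-nitrogen substituent in a weakly binding series

A few compounds are considered here, and "the series" means these few. Any claim that something is new, unique, unknown or untested is made for them only; others in the source may bear on it.

Measured so far:
Compound 1 `Cc1cccc2sc(NC(=O)CCN3CCN(CCN(C)C)CC3)nc12` gives > 1000 nM in an assay on membranes from liver for displacement of a labelled ligand from Sigma intracellular receptor 2 (Rattus norvegicus), read by scintillation counting, with a stated time of 120 min (on this read-out lower numbers stand for stronger inhibition and higher numbers for weaker inhibition), a limit of the assay.
Compound 2 `Cc1cccc2sc(NC(=O)CCN3CCN(C4CCN(C)CC4)CC3)nc12` gives 3600 nM in this assay.
Compound 3 `Cc1ccccc1N1CCN(CCC(=O)Nc2nc3c(C)cccc3s2)CC1` gives > 1000 nM in this assay, a limit of the assay.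

Compound 1 is known only as a limit in this assay, so its true value is not pinned down. Of the three compounds, two sit at a limit, and only compound 2 carries a number. The steps from compound 1 to compound 2 a step that the limit leaves unreadable from compound 1 to compound 2, from compound 1 to compound 3 a step that the two limits leave unreadable from compound 1 to compound 3 and from compound 2 to compound 3 a step that the limit leaves unreadable from compound 2 to compound 3 cannot be sized, because of the limit of > 1000 nM in this assay, at which 2 of the 3 values shown sit.

Compound 4 `Cc1cccc2sc(NC(=O)CCN3CCN(c4ccccn4)CC3)nc12` differs from compound 1 by pyridin-2-yl in place of 2-(dimethylamino)ethyl on an amine nitrogen in a ring. The measured steps around compound 1 give no readable size or direction, so no step beyond the scatter can be expected, only continued weak binding. Compound 4 is therefore estimated at 3000 nM, within 800 nM to 15000 nM. This estimate means a step from compound 1 to compound 4 of a step that the limit leaves unreadable from compound 1 to compound 4, and a limit rather than a number is judged the more likely outcome.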

Compound 4, inhibition constant: > 1000 nM
Compound 4 gave a limit, no number; the forecaster's own chance of this, stated with the estimate: 60%; the middle value does not contradict the limit.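

Compound 4 gives only a limit in this assay, so its steps to compound 1, compound 2 and compound 3 cannot be read: the limit of > 1000 nM in this assay, at which 3 of the 4 values shown sit. The compounds shown leave open how these four substituents on the ring nitrogen truly rank, and whether swapping them changes binding at all.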